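Coumarin ether series: a chloro added to the benzyl group

A few compounds are considered here, and "the series" means these few. Any claim that something is new, unique, unknown or untested is made for them only; others in the source may bear on it.

Compound 1, `Cc1c(C)c2ccc(OC3CCN(C)CC3)cc2oc1=O`, gives 11700 nM in an assay for inhibition of Amine oxidase [flavin-containing] A (Homo sapiens), read by fluorescence, using microsomes, with stated times of 20 min and 30 min; a lower number here means a stronger inhibitor, a higher number a weaker inhibitor.
Compound 2, `Cc1c(C)c2ccc(OC3CCN(Cc4ccccc4)CC3)cc2oc1=O`, gives 3590 nM in this assay.

Compound 2 has the lowest number of the two, with compound 1 the nearest neighbour. For the measured compounds named here, the one measured step, a 3.3-fold lower number from compound 1 to compound 2 (0.51 log units; beyond the scatter), changed the group on the ring nitrogen. Compound 3, `Cc1c(C)c2ccc(OC3CCN(Cc4cccc(Cl)c4)CC3)cc2oc1=O`, differs from compound 2 by chloro in place of hydrogen on an aromatic carbon. Going by the values given here, no measured step touches the benzyl ring itself, so the direction of this change is open; a small shift, within or just beyond the scatter, is expected. Compound 3 is estimated at 2500 nM, between 800 nM and 8000 nM, meaning an expected step of a 1.4-fold lower number from compound 2 to compound 3 (0.16 log units; within the scatter).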

Compound 3, half-maximal inhibitory concentration: 870 nM
For compound 3 the middle estimate is 2.9-fold (0.46 log units) above the measured one; low and high end bracket the measured number.
By their numbers in this assay, from the lowest: compound 3; then compound 2; then compound 1.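

The benzyl ring proves to be a position that responds to change: in this assay, chloro in place of hydrogen on an aromatic carbon gives a 4.1-fold lower number from compound 2 to compound 3 (0.62 log units; beyond the scatter) and so extends the gain from the benzyl group. Replacing the hydrogen on the chain carbon with 3-chlorophenyl gives a 13-fold lower number from compound 1 to compound 3 (1.13 log units; beyond the scatter) in all. Nothing available explains this gain.

From the compounds shown here alone, it remains open whether chloro would give the same result on another carbon of this ring. Going by these compounds, it is equally open whether bromo, methoxy or a nitrile could replace it here.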